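The source may report more compounds than this note shows. Statements on the series, on what has been measured and on what is new or still open speak of the compounds shown alone.

Working notes on a short series of anilides on a shared core. Compound 1 `O=C(CCc1ccccc1)Nc1cccc(-c2nc3ccccc3[nH]2)c1` gives 68000 nM in an assay on cells for inhibition of matrix metalloproteinase-9 (Homo sapiens), read by fluorescence, with stated times of 15 min and 4 h; on this read-out higher numbers stand for weaker inhibition and lower numbers for stronger inhibition. Compound 2 `Cc1cccc2nc(-c3cccc(NC(=O)CCCc4ccccc4)c3)[nH]c12` gives 38600 nM in this assay. Compound 3 `O=C(CCCc1ccccc1)Nc1ccc(-c2nc3ccccc3[nH]2)cc1` returns only > 100000 nM in this assay, and this is a limit of the assay, not a number. Compound 3 therefore stands at the limit of > 100000 nM in this assay, at which 1 of the 3 values shown sits, so it has no value of its own on the numbers shown, and no step between measured compounds is set out for the series. The next compound, compound 4 `O=C(CCCc1ccccc1)Nc1ccc(-c2nc3ccc(Br)cc3[nH]2)cc1`, differs from compound 3 in one place: bromo in place of hydrogen on an aromatic carbon. Going by the values given here, no measured pair carries this change, so its direction in this assay is open, and the working expectation is a step no larger than the usual scatter, in either direction. The expected step in this assay is a number no higher from compound 3 to compound 4 (the limit leaves the size open). Compound 4 is accordingly estimated at 100000 nM, with a range from 30000 nM to 300000 nM, and a real chance that this assay again returns only a limit.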

Compound 4, half-maximal inhibitory concentration: 58000 nM
Beside the measured number, compound 4's estimate is 1.7-fold (0.24 log units) above it, within the range that was stated.
By their numbers in this assay, from the lowest: compounds 2, 4 and 1 (each within the scatter of the next). At a limit, above all of these: compound 3.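

On an aromatic carbon of a six-membered aromatic ring of carbon only, part of a fused or bridged system of two rings, bromo in place of hydrogen gives an at least 1.7-fold lower number from compound 3 to compound 4 (0.23 log units; that floor lies within the scatter) in this assay. Going by these compounds alone, this is the first read on any change at this position, and compound 4 gives 58000 nM, a number rather than a limit. The value of compound 3 is a limit of the assay and not a number, so the full size of the step stays unfixed because of where compound 3 stands: the limit of > 100000 nM in this assay, at which 1 of the 4 values shown sits.

Going by these compounds, whether the true step lies beyond the scatter remains open, and this single pair cannot show whether the same change would act alike in compound 1. Also open, on these data alone, is what chloro, an amine or a carboxylic acid would do at this same carbon.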